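This account rests on a few compounds, and the source may have more. Where it says the series, first, only, none or still open, it means among the compounds named here.

Measured so far in a functional assay on HL-60 cells (Homo sapiens) for antiproliferative activity, with a stated time of 72 h; a higher number here means a weaker inhibitor, a lower number a stronger inhibitor:
compound 1 `OC[C@H]1O[C@@H](n2cnc3c(NCc4ccccc4F)ncnc32)[C@H](O)[C@@H]1O`: 3200 nM
compound 2 `OC[C@H]1O[C@@H](n2cnc3c(NCc4cccc(Br)c4)ncnc32)[C@H](O)[C@@H]1O`: 8000 nM
compound 3 `OC[C@H]1O[C@@H](n2cnc3c(NCc4c(F)ccc(F)c4F)ncnc32)[C@H](O)[C@@H]1O`: 13000 nM

Among these three numbers compound 2 holds the second highest. Its nearest neighbour is compound 3, with a gap of a 1.6-fold higher number from compound 2 to compound 3 (0.21 log units; within the scatter), inside the scatter; its furthest is compound 1, with a gap of a 2.5-fold higher number from compound 1 to compound 2 (0.40 log units; beyond the scatter).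

Compound 4 `OC[C@H]1O[C@@H](n2cnc3c(NCc4ccc(F)c(Cl)c4)ncnc32)[C@H](O)[C@@H]1O` has not yet been measured in this assay. Against compound 2 the change is 3-chloro-4-fluorophenyl in place of 3-bromophenyl on a saturated chain carbon bound to a nitrogen on an aromatic ring.

Steps that bear on it: a 2.5-fold higher number from compound 1 to compound 2 (0.40 log units; beyond the scatter) and a 4.1-fold higher number from compound 1 to compound 3 (0.61 log units; beyond the scatter) both show that leaving the 2-fluorophenyl of compound 1 for a differently halogenated ring raises the number modestly, while a 1.6-fold higher number from compound 2 to compound 3 (0.21 log units; within the scatter) shows that exchanging one such halogenated ring for another moves little. Within the data shown here, no measured step replaces bromine with chlorine or adds a fluorine to a 3-halophenyl, so the present change has no direct anchor. Since the two halogenated rings already measured sit close together, the expected step in this assay is small, a 1.1-fold higher number from compound 2 to compound 4 (0.05 log units; within the scatter), with no direction clearly beyond the scatter. Compound 4 is therefore estimated at 9000 nM, in the range 4000 nM to 20000 nM.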

Compound 4, half-maximal inhibitory concentration: 3500 nM
Beside the measured number, compound 4's estimate is 2.6-fold (0.41 log units) above it, and the stated range ends above it.
By their numbers in this assay, from the lowest: compounds 1 and 4 (each within the scatter of the next); then compounds 2 and 3 (each within the scatter of the next).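

In this assay, the halogenated phenyl group on a saturated chain carbon bound to a nitrogen on an aromatic ring now shows that one halogenated ring in place of another can matter: the result gives a 2.3-fold lower number from compound 2 to compound 4 (0.36 log units; beyond the scatter) and a 3.7-fold lower number from compound 3 to compound 4 (0.57 log units; beyond the scatter), both beyond the scatter, whereas the earlier exchange between the rings of compound 2 and compound 3 stayed within it. With a 1.1-fold higher number from compound 1 to compound 4 (0.04 log units; within the scatter), the 3-chloro-4-fluorophenyl and 2-fluorophenyl groups cannot be told apart in this read-out, so two differently substituted rings share the low end of the series while compound 2 and compound 3 stay at the high end. Nothing at hand accounts for this split among the four rings.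

The change from compound 2 to compound 4 swaps bromine for chlorine and adds fluorine together, so the compounds shown cannot assign the step to either part; rings carrying chlorine alone or fluorine alone would separate them. Also open, from the compounds shown here alone, is how this position responds to something other than a halogenated phenyl, such as an unsubstituted phenyl, a methoxy group on the ring, or a longer chain to the ring.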